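Chloro in place of hydrogen on the phenyl ring of compound 1

A few compounds are considered here, and "the series" means these few. Any claim that something is new, unique, unknown or untested is made for them only; others in the source may bear on it.

Measured compounds:
compound 1 `N=C(NCCCc1c[nH]cn1)NCCC(c1ccccc1)c1ccccn1`: 7.39
compound 2 `Cc1ccc(C(CC/N=C(\N)NCCCc2c[nH]cn2)c2ccccn2)cc1`: 7.71

Both compounds were tested in a functional assay on cardiac atrium for agonist activity at histamine H2 receptor (Cavia porcellus); a higher number here means a more potent compound, by a factor of ten per unit of this negative logarithm, a lower number a less potent compound. Compound 1 gives 7.39, the lower of the two numbers; compound 2 gives 7.71, a gap above compound 1 that goes beyond the usual scatter of such measurements.

Compound 3 `N=C(NCCCc1c[nH]cn1)NCCC(c1ccc(Cl)cc1)c1ccccn1` has not yet been measured. It differs from compound 1 in a single place: chloro in place of hydrogen on an aromatic carbon. For the measured compounds named here, no measured pair shows exactly this step, so its size can only be judged from the neighbouring evidence. Compound 2 also carries one small added group on the same ring, and its value in this assay lies above that of compound 1 by an amount beyond the scatter. On that basis a modest rise is expected for compound 3 in this assay, estimated as a number 0.21 log units higher from compound 1 to compound 3 (within the scatter). The expected value for compound 3 in this assay is 7.6, with a range from 7.1 to 8.1.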

Compound 3, negative logarithm of the half-maximal effective concentration: 7.84
For compound 3 the middle estimate is 0.24 log units below the measured one; the measured number falls inside the stated range.
By their numbers in this assay, from the lowest: compound 1; then compounds 2 and 3 (each within the scatter of the next).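

In this assay, for the compounds shown here, chloro in place of hydrogen gives a number 0.45 log units higher from compound 1 to compound 3 (beyond the scatter), the first directly measured single change on this phenyl ring, and it shows that this position accepts a chlorine atom with a gain rather than a loss. Compound 2, which carries methyl at the same place, and compound 3 lie within the scatter of each other, so this assay does not separate these two groups. No measurement shown here explains the gain.

Going by these compounds, whether the gain extends to other groups at this place, such as fluoro, methoxy, trifluoromethyl or an amine, remains open. Also open, on these data alone, is how a larger group such as a second phenyl ring would behave, and whether chloro would give a similar step on the other ring of the shared core.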